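A few compounds are considered here, and "the series" means these few. Any claim that something is new, unique, unknown or untested is made for them only; others in the source may bear on it.

Compound 1 `O=C(O)c1ccccc1-c1ccc(CCc2ncc(CC3CCC3)[nH]2)cc1` in an in vitro functional assay on cells for agonist activity at Bombesin receptor subtype-3 (Mus musculus), read by luminescence and calcium flux (a lower number here means that less compound is needed, a higher number that more compound is needed for the effect), gives 7.1 nM. For the measured compounds named here, compound 2 `N#Cc1ccc(Cc2cnc(CCc3ccc(-c4ccccc4C(=O)O)cc3)[nH]2)cc1` in this assay gives 723 nM, the highest of the two numbers so far; the step of a 100-fold higher number from compound 1 to compound 2 (2.01 log units; beyond the scatter) separates them. Compound 3 `N#Cc1cccc(Cc2cnc(CCc3ccc(-c4ccccc4C(=O)O)cc3)[nH]2)c1` differs from compound 2 by 3-cyanophenyl in place of 4-cyanophenyl on a saturated chain carbon bound to an aromatic carbon. Going by the values given here, no measured step exchanges one cyanophenyl for another, so the only step in hand bears on this change indirectly, having swapped cyclobutyl for an aryl group rather than moving a nitrile. For compound 3 the expected step of a 1.2-fold lower number from compound 2 to compound 3 (0.08 log units; within the scatter) is therefore none beyond the scatter. Compound 3 is estimated at 600 nM, within 150 nM to 3000 nM.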

Compound 3, half-maximal effective concentration: 20 nM
Compound 3: middle estimate off by 30-fold (1.48 log units), on the high side; measured number below the stated range.
By their numbers in this assay, from the lowest: compound 1; then compound 3; then compound 2.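

In this assay, moving the nitrile matters at this position: 3-cyanophenyl in place of 4-cyanophenyl gives a 36-fold lower number from compound 2 to compound 3 (1.56 log units; beyond the scatter) with the same atoms, so the large rise seen earlier does not hold for every cyanophenyl group here. Against cyclobutyl, the remaining gap is a 2.8-fold higher number from compound 1 to compound 3 (0.45 log units; beyond the scatter) and is still beyond the scatter, leaving compound 1 with the lowest number. Nothing on hand explains the difference between the two nitrile placements. Still open, on these data alone, is whether the nitrile is needed at all, which plain phenyl on the same carbon would show, and whether 3-chlorophenyl would behave like 3-cyanophenyl.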